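A Larger Aryl on the Ring Nitrogen Chain

The compounds below may be only part of what the source reports. "The series", "measured", "known", "first", "only" and "open" are said of these compounds alone.

Compound 1 `CCN1C(=O)C(=O)c2cc(-c3ccc(OC)cc3)ccc21` carries a methyl on the saturated chain carbon bound to the amide-type nitrogen in its ring. For the measured compounds named here, in a functional assay on K562 cells (Homo sapiens) for antiproliferative activity, read by MTT assay, with a stated time of 48 h (a lower number here means a stronger inhibitor, a higher number a weaker inhibitor), compound 1 gives 2200 nM, the highest of the three numbers measured so far. Compound 2 `COc1ccc(-c2ccc3c(c2)C(=O)C(=O)N3Cc2cccc(Cl)c2)cc1` gives 200 nM in this assay, and compound 3 `COc1ccc(-c2ccc3c(c2)C(=O)C(=O)N3Cc2cccc(OC)c2)cc1` gives 680 nM. The steps of an 11-fold lower number from compound 1 to compound 2 (1.04 log units; beyond the scatter) and a 3.2-fold lower number from compound 1 to compound 3 (0.51 log units; beyond the scatter) show that exchanging the methyl for a substituted phenyl lowered the number in both cases, while a 3.4-fold higher number from compound 2 to compound 3 (0.53 log units; beyond the scatter) shows that the two phenyl variants themselves differ by a modest step. Compound 4 `COc1ccc(-c2ccc3c(c2)C(=O)C(=O)N3Cc2ccc3ccccc3c2)cc1` differs from compound 1 as follows: naphthalen-2-yl in place of methyl on a saturated chain carbon bound to an amide-type nitrogen in a ring. The two measured aryl-for-methyl steps bear on it most directly, one large and one modest, both downward. Going by the values given here, no measured compound carries two fused aromatic rings at this place, so the exact size cannot be read from the data, but a lowering beyond the scatter is expected, with a 7.3-fold lower number from compound 1 to compound 4 (0.87 log units; beyond the scatter). Compound 4 is therefore estimated at 300 nM, with a range from 80 nM to 1200 nM.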

Compound 4, half-maximal inhibitory concentration: 400 nM
Compound 4: the middle estimate sits 1.3-fold (0.12 log units) below what was measured; the measured number falls inside the stated range.
By their numbers in this assay, from the lowest: compounds 2, 4 and 3 (each within the scatter of the next, the first and the last beyond it); then compound 1.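

In this assay, naphthalen-2-yl at this place also improves on methyl, a 5.5-fold lower number from compound 1 to compound 4 (0.74 log units; beyond the scatter), so the lowering seen with the chloro- and methoxy-substituted phenyl groups extends to an unsubstituted group of two fused aromatic rings. The larger group cannot be told apart from either phenyl group, with a 1.7-fold lower number from compound 3 to compound 4 (0.23 log units; within the scatter) and a 2.0-fold higher number from compound 2 to compound 4 (0.30 log units; within the scatter) both within the scatter, even though compounds 2 and 3 differ from each other beyond it. No supporting measurement accompanies these results to say what lies behind them.

From the compounds shown here alone, it remains open how a cyclohexyl ring or a longer alkyl chain on the ring nitrogen would compare with these aryl groups. Also open, going by these compounds, is what an amine or a carboxylic acid on the aryl ring would do to the number.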